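A few compounds are considered here, and "the series" means these few. Any claim that something is new, unique, unknown or untested is made for them only; others in the source may bear on it.

Values in a functional assay on A549 cells (Homo sapiens) for cytotoxicity, read by MTT assay, with a stated time of 24 h (on this read-out higher numbers stand for weaker inhibition and lower numbers for stronger inhibition), so far:
- compound 1 `C/C(=N\NC(=O)/C(C#N)=C/c1ccccc1)c1c(O)c2ccc(O)cc2oc1=O` gives 14800 nM
- compound 2 `COc1cc(/C=C(\C#N)C(=O)N/N=C(\C)c2c(O)c3ccc(O)cc3oc2=O)ccc1O` gives 12600 nM
- compound 3 `COc1ccc(/C=C(\C#N)C(=O)N/N=C(\C)c2c(O)c3ccc(O)cc3oc2=O)cc1` gives 8150 nM

Compound 3 (8150 nM) stands in one group with the other two values, and no order can be read among them. The next compound, compound 4 `C/C(=N\NC(=O)/C(C#N)=C/c1ccc(Br)cc1)c1c(O)c2ccc(O)cc2oc1=O`, carries bromo in place of methoxy on an aromatic carbon, para to a large group, so 4-methoxyphenyl becomes 4-bromophenyl (bromo in place of methoxy on an aromatic carbon).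

Among the compounds with values here, two measured steps touch this same group. Placing methoxy on that aromatic carbon gave a 1.8-fold lower number from compound 1 to compound 3 (0.26 log units; within the scatter), and exchanging the aryl group of compound 2 gave a 1.5-fold lower number from compound 2 to compound 3 (0.19 log units; within the scatter). Within the data shown here, no measured compound carries bromo, so these steps give only a rough guide to size. With both of those steps small, no shift beyond the scatter is expected in this assay.

The expected change is a 1.2-fold higher number from compound 3 to compound 4 (0.07 log units; within the scatter). For compound 4 the estimated value is 9500 nM, with an expected range from 4500 nM to 20000 nM.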

Compound 4, half-maximal inhibitory concentration: 11400 nM
The estimate for compound 4 lay 1.2-fold (0.08 log units) below the measured number; the range from low to high includes it.
By their numbers in this assay, from the lowest: compounds 3, 4, 2 and 1 (each within the scatter of the next).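

In this assay, bromo on this aromatic carbon, para to a large group, stays within the scatter of both methoxy (a 1.4-fold higher number from compound 3 to compound 4 (0.15 log units; within the scatter)) and hydrogen (a 1.3-fold lower number from compound 1 to compound 4 (0.11 log units; within the scatter)). Exchanging the whole aryl group of the 4-hydroxy-3-methoxyphenyl compound for 4-bromophenyl also stays within it (a 1.1-fold lower number from compound 2 to compound 4 (0.04 log units; within the scatter)), so the flat picture now extends to a substituent holding a bromine atom and no oxygen, and all four compounds remain one group without an order. No measurement is at hand that would account for this flat result.

On these data alone, whether an amine or a carboxylic acid on this aromatic carbon would move the number beyond the scatter remains open. Also open, as far as these compounds go, is whether any change at this position can separate compounds on this read-out.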